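The source may hold more compounds than are shown below. What is called first, only, known or untested is meant among the compounds shown, and "the series" means these compounds.

Compound 3 `Clc1cccc(-c2cc(-c3ccc(Cl)o3)cc(-c3cccs3)n2)c1` gives 8.5% in an assay on isolated protein for inhibition of DNA topoisomerase 1 (Homo sapiens), tested at 20 uM; a lower number here means a weaker effect, a higher number a stronger effect of the compound at the concentration tested. For comparison, compound 1 `Clc1ccc(-c2cc(-c3cccs3)nc(-c3ccccc3Cl)c2)o1` gives 8% in this assay, and compound 2 `Clc1ccc(-c2cc(-c3ccc(Cl)o3)cc(-c3ccsc3)n2)cc1` gives 5.2% in this assay. Compound 3 thus holds the highest of the three numbers, yet its gap to compound 1 and its gap to compound 2 both lie within the usual scatter, so the three compounds cannot be told apart on these data. Among the measured compounds shown here, the only step between compounds that differ in one place, a number 0.5 percentage points higher from compound 1 to compound 3 (within the scatter), is within the scatter as well.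

Compound 4 `Cc1ccc(-c2cc(-c3ccc(Cl)o3)cc(-c3cccs3)n2)cc1` differs from compound 3 in a single place: 4-methylphenyl in place of 3-chlorophenyl on an aromatic carbon. For the measured compounds named here, no measured step exchanges a chlorophenyl for a methylphenyl, so nothing bears directly on this change. Going by the values given here, the one related step, a number 0.5 percentage points higher from compound 1 to compound 3 (within the scatter), moved one chlorophenyl to another and produced no effect beyond the scatter, and all three measured compounds sit in the same low region. Compound 4 is therefore expected to stay in that region, with a step of a number 1.5 percentage points lower from compound 3 to compound 4 (within the scatter) that is not expected to exceed the scatter. The estimate for compound 4 in this assay is 7%, with a range from 0% to 16%.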

Compound 4, a percentage reported as inhibition, at one concentration (the size of the read-out at that concentration, not a potency): 9.3%
Compound 4: middle estimate off by 2.3 percentage points, on the low side, and the stated range covers the measured number.
By their numbers in this assay, from the lowest: compounds 2, 1, 3 and 4 (each within the scatter of the next).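

In this assay the exchange of 3-chlorophenyl for 4-methylphenyl on the aromatic carbon next to the ring nitrogen gives a number 0.8 percentage points higher from compound 3 to compound 4 (within the scatter) and the exchange of 2-chlorophenyl for the same group gives a number 1.3 percentage points higher from compound 1 to compound 4 (within the scatter) at that carbon. Compounds 1, 2 and 3 all carry a chlorine on this phenyl ring, whereas compound 4 carries a methyl group there and has no chlorine on that ring, and its number cannot be told apart from those of compound 1 and compound 3, so chlorine on this ring is not needed to keep the read-out in the same low region. Nothing at hand bears on why this exchange leaves the read-out within the scatter.

All the groups shown at this position are phenyl rings carrying a single chlorine or methyl, so it remains open whether an amine, a carboxylic acid or a longer alkyl chain on this ring would give a number beyond the scatter. On these data alone, it is equally open whether any exchange at the thiophen-2-yl or 5-chlorofuran-2-yl groups would lift these compounds out of the low region.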